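The source may hold more compounds than are shown below. What is called first, only, known or untested is meant among the compounds shown, and "the series" means these compounds.

In an ADME assay on the whole organism (Mus musculus, strain Swiss) for metabolic stability, read by LC-MS, with a stated time of 24 h, at a dose of 20 mg/kg by the oral route (a higher number here means that the compound lasts longer, a lower number that the compound disappears faster), compound 1 (`Cc1c(Cc2ccc(C(F)(F)F)nc2)c[nH]c1C(=O)NC(C)c1cnn(C)c1`) gives 3.5 h and compound 2 (`Cc1cc(C(C)NC(=O)c2[nH]cc(Cc3ccc(C(F)(F)F)nc3)c2C)no1`) gives 2.3 h. For the measured compounds named here, these two numbers lie within the scatter of each other, so compound 2 stands level with the only other compound measured so far. Compound 3 (`Cc1c(Cc2ccc(C(F)(F)F)nc2)c[nH]c1C(=O)NC(C)c1cn[nH]c1`) has 1H-pyrazol-4-yl in place of 5-methyl-1,2-oxazol-3-yl on a saturated chain carbon bound to an amide-type nitrogen and a saturated chain carbon. Going by the values given here, only one measured step bears on this change, as it swaps a ring at the same place: a 1.5-fold lower number from compound 1 to compound 2 (0.18 log units; within the scatter). One small step is thin evidence, but it gives no reason to expect a large change. The expected step is a 1.3-fold higher number from compound 2 to compound 3 (0.12 log units; within the scatter), which would stay within the scatter. Compound 3 is expected at 3 h, with an estimated range from 1.4 h to 6 h.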

Compound 3, half-life: 4.4 h
For compound 3 the middle estimate is 1.5-fold (0.17 log units) below the measured one, within the range that was stated.
By their numbers in this assay, from the lowest: compounds 2, 1 and 3 (each within the scatter of the next).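

In this assay, the bare 1H-pyrazol-4-yl ring gives a 1.9-fold higher number from compound 2 to compound 3 (0.28 log units; within the scatter), so a ring with a hydrogen-bond donor can replace 5-methyl-1,2-oxazol-3-yl at this place without a step beyond the scatter. The other new comparison is a different kind of change, hydrogen in place of methyl on an aromatic nitrogen, and it gives a 1.3-fold higher number from compound 1 to compound 3 (0.10 log units; within the scatter), so the half-life of this pair does not depend measurably on that methyl. Nothing available explains why these steps are small.

On these data alone, all three compounds carry a five-membered aromatic ring at this place, so it remains open whether a phenyl ring or an open chain bearing an amine would move the half-life beyond the scatter. As far as these compounds go, the effect of changes elsewhere, such as to the trifluoromethyl group, also remains open.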